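The compounds below may be only part of what the source reports. "The series", "measured", "known", "first", "only" and "open" are said of these compounds alone.

Measured so far in an ADME assay on J774 cells (Mus musculus) for cytotoxicity, read by MTT assay, with a stated time of 48 h, tested at 50 ug/mL; on this read-out higher numbers stand for a weaker effect at the one concentration tested and lower numbers for a stronger effect:

Compound 1, `O=C(N/N=C/c1ccccc1F)c1cnccn1`: compound 1 gives 100%.
Compound 2, `O=C(N/N=C/c1ccccc1O)c1cnccn1`: compound 2 gives 1%.

Compound 2 stands lowest of the two numbers; its nearest neighbour is compound 1, whose value sits far higher, beyond the scatter. Going by the values given here, the only measured step is a number 99 percentage points lower from compound 1 to compound 2 (beyond the scatter), a large drop that came with hydroxy in place of fluoro on an aromatic carbon.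

Compound 3, `N#Cc1ccccc1/C=N/NC(=O)c1cnccn1`, is not yet measured. It differs from compound 2 by cyano in place of hydroxy on an aromatic carbon. This step removes the hydroxy whose entry went along with the large drop from compound 1 to compound 2, and cyano, like fluoro in compound 1, carries no hydrogen-bond donor. Among the compounds with values here, the step from compound 1 to compound 2 therefore bears directly on it, and a step in this assay upward, back toward the value of compound 1, is expected, though no measured step covers cyano itself, so the size is uncertain. The estimate for compound 3 is 70%, within 20% to 100%. This estimate means a step of a number 69 percentage points higher from compound 2 to compound 3 (beyond the scatter).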

Compound 3, a percentage reported as activity, at one concentration (the size of the read-out at that concentration, not a potency): 92%
Compound 3: middle estimate off by 22 percentage points, on the low side; low and high end bracket the measured number.
By their numbers in this assay, from the lowest: compound 2; then compounds 3 and 1 (each within the scatter of the next).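

In this assay the step of a number 91 percentage points higher from compound 2 to compound 3 (beyond the scatter) shows that the low number of compound 2 does not survive a second replacement of hydroxy at this place, on an aromatic carbon ortho to a large group. The step of a number 8 percentage points lower from compound 1 to compound 3 (within the scatter) places cyano level with fluoro, so among these three compounds only the hydroxy compound stands apart, and two different groups without hydroxy give matching numbers. Hydroxy leaves with 1 hydrogen-bond donor and cyano enters with 0 hydrogen-bond donors, but no measured evidence ties the difference to that count or to anything else.

Still open, going by these compounds, is whether an amine or a methoxy group at this place follows hydroxy or follows fluoro and cyano. Also open, on these data alone, is whether hydroxy elsewhere on the same ring gives a similarly low number.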